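This account rests on a few compounds, and the source may have more. Where it says the series, first, only, none or still open, it means among the compounds named here.

Compound 1 `CCc1ccc2nc(C(=O)Nc3c(F)cc(-c4cccc(F)c4)cc3F)c(C)c(O)c2c1`: 56.3%
Compound 2 `CCOc1ccc2nc(C(=O)Nc3c(F)cc(-c4cccc(F)c4)cc3F)c(C)c(O)c2c1`: 11.2%
Compound 3 `Cc1c(C(=O)Nc2c(F)cc(-c3cccc(F)c3)cc2F)nc2ccc(C(F)(F)F)cc2c1O`: 45.2%

All three were measured in a functional assay on Hep 3B2 cells (Homo sapiens) for antiproliferative activity, read by MTT assay, with a stated time of 24 h, tested at 33.33 ug/mL; on this read-out higher numbers stand for a stronger effect at the one concentration tested and lower numbers for a weaker effect. Compound 1 gives the highest of the three numbers. The nearest is compound 3, reached by a step of a number 11.1 percentage points lower from compound 1 to compound 3 (beyond the scatter), and the furthest is compound 2, reached by a step of a number 45.1 percentage points lower from compound 1 to compound 2 (beyond the scatter). Between the two lower compounds the step runs upward, a number 34 percentage points higher from compound 2 to compound 3 (beyond the scatter). Each of these steps exchanges one group on an aromatic carbon of the shared core: ethoxy in place of ethyl, trifluoromethyl in place of ethyl, or trifluoromethyl in place of ethoxy.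

Compound 4 `CCc1ccc2nc(C(=O)Nc3c(F)cc(-c4cccc(F)c4)cc3F)c(C)c(C(=O)O)c2c1` has not yet been measured in this assay. It keeps the ethyl group of compound 1 and differs from it at a different point: carboxy in place of hydroxy on an aromatic carbon. The exchange sits on an aromatic carbon of a six-membered aromatic ring with one nitrogen, part of a fused system of two rings, ortho to a methyl group and opposite the ring nitrogen.

Within the data shown here, none of the measured steps touches the hydroxy group; all three vary only the ethyl position. The data thus give no direct guide to the size or direction of this change, and the expectation is correspondingly uncertain. The step is estimated as a number 18.3 percentage points lower from compound 1 to compound 4 (beyond the scatter). Compound 4 is expected to give about 38%, within a range from 8% to 65%.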

Compound 4, a percentage reported as inhibition, at one concentration (the size of the read-out at that concentration, not a potency): 36.3%
Compound 4: middle estimate off by 1.7 percentage points, on the high side; low and high end bracket the measured number.
By their numbers in this assay, from the lowest: compound 2; then compounds 4 and 3 (each within the scatter of the next); then compound 1.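

Among these compounds, changing the group at the hydroxy position also moves the result in this assay, a place none of the earlier compounds varied: carboxy in place of hydroxy gives a number 20 percentage points lower from compound 1 to compound 4 (beyond the scatter), and this step is read on an unchanged ethyl group. Compound 4 gives 36.3% with carboxy on this aromatic carbon, so in this series a hydroxy group there is not needed for a measurable effect at the one concentration tested, although compound 1 with its hydroxy group keeps the higher number. Nothing available here accounts for the drop. The compounds shown leave open how other groups at this place would compare, for example an amine, a methoxy group or a primary amide, and whether any of them would match or exceed the number of compound 1. As far as these compounds go, it also remains open whether the step from hydroxy to carboxy would keep its size and direction with ethoxy or trifluoromethyl in place of the ethyl group, since this change is seen on the ethyl compounds alone.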